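Moving the hydroxy group around the outer ring

The source may report more compounds than this note shows. Statements on the series, on what has been measured and on what is new or still open speak of the compounds shown alone.

Measured compounds:
compound 1, `CCCCCCCCS(=O)(=O)Nc1ccc(-c2ccccc2F)cc1C(=O)O`, 34600 nM
compound 2, `CCCCCCCCS(=O)(=O)Nc1ccc(-c2ccccc2O)cc1C(=O)O`, 61700 nM

Both compounds were tested in an assay on mitochondria (strain BALB/c) for inhibition of glycerol-3-phosphate acyltransferase 1, mitochondrial (Mus musculus), read by scintillation counting, with a stated time of 10 min; on this read-out lower numbers stand for stronger inhibition and higher numbers for weaker inhibition. Compound 2 gives 61700 nM, the highest of the two numbers, while its nearest neighbour, compound 1, gives 34600 nM; the step of a 1.8-fold higher number from compound 1 to compound 2 (0.25 log units; within the scatter) lies within the scatter, so the two cannot be told apart. Compound 3, `CCCCCCCCS(=O)(=O)Nc1ccc(-c2ccc(O)cc2)cc1C(=O)O`, differs from compound 2 by 4-hydroxyphenyl in place of 2-hydroxyphenyl on an aromatic carbon. Going by the values given here, no measured step touches this kind of change: the one known step swaps one small group for another at a fixed place, and it was itself within the scatter. There is therefore no basis for expecting a change beyond the scatter in this assay in either direction. Compound 3 is estimated at 50000 nM, with a range from 15000 nM to 160000 nM, which means an expected step of a 1.2-fold lower number from compound 2 to compound 3 (0.09 log units; within the scatter).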

Compound 3, half-maximal inhibitory concentration: 47300 nM
Beside the measured number, compound 3's estimate is 1.1-fold (0.02 log units) above it; the measured number falls inside the stated range.
By their numbers in this assay, from the lowest: compounds 1, 3 and 2 (each within the scatter of the next).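

Shifting the hydroxy group from 2-hydroxyphenyl to 4-hydroxyphenyl gives a 1.3-fold lower number from compound 2 to compound 3 (0.12 log units; within the scatter) in this assay and so shows that, for these two compounds, where the hydroxy group sits on the outer ring makes no difference that can be read. The earlier pair tested only a swap of one small group for another at a fixed place, whereas here the place itself differs. Replacing 2-fluorophenyl with 4-hydroxyphenyl, which alters both the group and its place, gives a 1.4-fold higher number from compound 1 to compound 3 (0.14 log units; within the scatter) and likewise leaves the two compounds indistinguishable.

No measurement shown here offers an explanation for these results.

On these data alone, it remains open whether an amine or a carboxylic acid on the outer ring would give a step beyond the scatter. The compounds shown also leave open what a longer chain in place of the shared one would do.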